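The source may report more compounds than this note shows. Statements on the series, on what has been measured and on what is new or still open speak of the compounds shown alone.

Measured compounds:
- Compound 1, `Cn1c(=O)c2c(nc(COc3cccc(Br)c3)n2C)n(C)c1=O`, in an in vitro assay on cells for inhibition of Amine oxidase [flavin-containing] B (Homo sapiens), read by coupled enzyme assay, with a stated time of 20 min (a lower number here means a stronger inhibitor, a higher number a weaker inhibitor), compound 1 gives 148 nM.
- Compound 2, `Cn1c(=O)c2c(nc(CCSc3ccc(Cl)cc3)n2C)n(C)c1=O`, in this assay compound 2 gives 7790 nM.

Within the data shown here, compound 2 stands at the highest of the two numbers in this assay; compound 1 sits well beyond the scatter from it, so the two values are clearly different, but the two structures differ in more than one place and no single step between them can be read. The two values are taken only for what they show: compound 2 is the weaker inhibitor of the pair.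

Compound 3, `Cn1c(=O)c2c(nc(CCSc3ccc(Br)cc3)n2C)n(C)c1=O`, is not yet measured. It differs from compound 2 in one place: bromo in place of chloro on an aromatic carbon. Bromo in place of chloro on an aromatic carbon is a small exchange of one halogen for another, and nothing in the measured pair speaks to its size here. The expectation is a step from compound 2 to compound 3 in this assay of a 1.3-fold lower number from compound 2 to compound 3 (0.11 log units; within the scatter), that is none beyond the scatter, perhaps a slightly lower number. For compound 3 in this assay the estimate is 6000 nM, with a range from 2500 nM to 15000 nM.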

Compound 3, half-maximal inhibitory concentration: 124000 nM
The estimate for compound 3 lay 21-fold (1.32 log units) below the measured number; measured number outside the range, above it.
By their numbers in this assay, from the lowest: compound 1; then compound 2; then compound 3.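

In this assay, the exchange of chloro for bromo on an aromatic carbon, para to a large group, gives a 16-fold higher number from compound 2 to compound 3 (1.20 log units; beyond the scatter), so this position of the (4-chlorophenyl)sulfanyl group responds strongly to the identity of its halogen. The earlier pair differed in more than one place and could not isolate any single change; this step comes from one heavy atom replaced by one heavy atom, with no change in ring count, hydrogen-bond donors, hydrogen-bond acceptors or net charge. No measurement available here accounts for the size of this step.

Only chloro and bromo are shown at this position, so it remains open how a fluoro, a methoxy or an amine in the same place would read in this assay, and whether the number follows any order across such groups. On these data alone, it also remains open whether chloro in place of bromo on the aromatic ring of compound 1 would give a step of similar size, or whether the sensitivity seen here belongs to the (4-chlorophenyl)sulfanyl series alone.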